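Swapping Nitro for Chlorophenyl on the Furan-Bearing Amide

A few compounds are considered here, and "the series" means these few. Any claim that something is new, unique, unknown or untested is made for them only; others in the source may bear on it.

compound 1 `O=C(Nc1ncc([N+](=O)[O-])s1)c1cc(Cl)ccc1O` gives 63% in an ADME assay on HEK-293T cells (Homo sapiens) for cytotoxicity, read by MTT assay, tested at 100 uM; a lower number here means a stronger effect, a higher number a weaker effect of the compound at the concentration tested
compound 2 `O=C(Nc1ncc([N+](=O)[O-])s1)c1cc(Cl)cc(Cl)c1O` gives 23.5% in this assay
compound 3 `O=C(Nc1ncc([N+](=O)[O-])s1)c1ccc([N+](=O)[O-])o1` gives 67.3% in this assay

Among these three numbers compound 3 stands highest, but compound 1 lies within the usual scatter of it, so the two cannot be ranked against each other; only compound 2 sits clearly lower. Compound 4 `O=C(Nc1ncc([N+](=O)[O-])s1)c1ccc(-c2ccc(Cl)cc2)o1` keeps the shared core of compound 3 and differs from it in one place: 4-chlorophenyl in place of nitro on an aromatic carbon.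

Among the measured compounds shown here, the one measured step, a number 39.5 percentage points lower from compound 1 to compound 2 (beyond the scatter), is large, and it also brought a chlorine onto an aromatic ring. It does not cover the present change, though: there the chlorine was added to a ring already carrying one, whereas here a nitro leaves and a whole chlorinated ring enters on a different ring. Taking that step as a rough guide, a decrease in this assay is expected, amounting to a number 25.3 percentage points lower from compound 3 to compound 4 (beyond the scatter). For compound 4 the estimated value is 42%, with a range from 12% to 78%.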

Compound 4, a percentage reported as activity, at one concentration (the size of the read-out at that concentration, not a potency): 74.1%
Compound 4: the middle estimate sits 32.1 percentage points below what was measured; low and high end bracket the measured number.
By their numbers in this assay, from the lowest: compound 2; then compounds 1, 3 and 4 (each within the scatter of the next, the first and the last beyond it).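

Putting 4-chlorophenyl in place of nitro gives in this assay a number 6.8 percentage points higher from compound 3 to compound 4 (within the scatter) and so cannot be told apart from no change. On this aromatic carbon next to the ring oxygen, nitro can thus give way to a bigger group holding a six-membered aromatic ring of carbon only, with no clear shift in the read-out. The large a number 39.5 percentage points lower from compound 1 to compound 2 (beyond the scatter) in the salicylamide-like pair therefore gives no general rule for groups carrying chlorine, since a chlorine-bearing group entering here brings no such drop.

Going by these compounds, whether an amine, a carboxylic acid or a plain phenyl ring without chlorine at this place would also leave the read-out unchanged remains open. No measurement offered here accounts for why this exchange leaves the number within the scatter.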